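Cyclohexanone bis-benzylidene series: toward compound 3

A few compounds are considered here, and "the series" means these few. Any claim that something is new, unique, unknown or untested is made for them only; others in the source may bear on it.

Measured so far:
compound 1 `COc1cccc(/C=C2\CCC/C(=C\c3ccc(O)c(O)c3)C2=O)c1OC` gives 4700 nM in a functional assay on MCF7 cells (Homo sapiens) for cytotoxicity, read by MTT assay, with a stated time of 72 h; a lower number here means a stronger inhibitor, a higher number a weaker inhibitor
compound 2 `COc1ccc(/C=C2\CCC/C(=C\c3ccccc3Br)C2=O)cc1OC` gives 9500 nM in this assay

Compound 2 holds the highest number of the two measured, with compound 1 as its nearest neighbour, a gap that lies beyond the usual scatter. The next compound, compound 3 `COc1ccc(/C=C2\CCC/C(=C\c3ccc(O)c(Cl)c3)C2=O)cc1OC`, is still to be measured in this assay. The change from compound 2 to compound 3 is 3-chloro-4-hydroxyphenyl in place of 2-bromophenyl on a double-bonded chain carbon bound to a double-bonded ring carbon.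

Among the measured compounds shown here, no step between two measured compounds of this pair is known, so the expectation rests on the two values. For the measured compounds named here, the only measured compound that carries a hydroxyl on a benzylidene arm, compound 1, gives the lower number, and the hydroxyl-bearing arm of compound 3 points the same way. A step of a 1.9-fold lower number from compound 2 to compound 3 (0.28 log units; within the scatter) is expected, a decrease in the number that lies near the edge of the scatter. Compound 3 is estimated at 5000 nM, with a range from 2000 nM to 15000 nM.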

Compound 3, half-maximal inhibitory concentration: 12300 nM
For compound 3 the middle estimate is 2.5-fold (0.39 log units) below the measured one, and the stated range covers the measured number.
By their numbers in this assay, from the lowest: compound 1; then compounds 2 and 3 (each within the scatter of the next).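

In this assay, among the compounds shown here, 3-chloro-4-hydroxyphenyl in place of 2-bromophenyl on a double-bonded chain carbon bound to a double-bonded ring carbon gives a 1.3-fold higher number from compound 2 to compound 3 (0.11 log units; within the scatter) and is the first one-place step. At this place, then, the two arms cannot be told apart by their numbers, even though the entering arm brings a hydrogen-bond donor and a hydrogen-bond acceptor that 2-bromophenyl lacks. No measurement at hand bears on why the number stays within the scatter.

This single step exchanges the halogen and adds the hydroxyl together, so the contribution of each remains unresolved. Going by these compounds, whether an amine or a carboxylic acid on this arm would shift the number beyond the scatter also remains open.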